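Series notes: a methoxy to hydroxy step

This account rests on a few compounds, and the source may have more. Where it says the series, first, only, none or still open, it means among the compounds named here.

compound 1 `COc1cccc(C(C)Sc2nc3c(cnn3C)c(=O)n2-c2ccccc2)c1` — 451 nM
compound 2 `Cn1ccc2c(=O)n(-c3ccccc3)c(SCc3cccc(F)c3)nc21` — 930 nM

In an assay on isolated protein for inhibition of aldehyde dehydrogenase 1A1 (Homo sapiens) (a higher number here means a weaker inhibitor, a lower number a stronger inhibitor), compound 1 gives 451 nM and compound 2 gives 930 nM. Compound 1 thus stands at the lowest of the two numbers, with compound 2 above it by a gap that is beyond the scatter. Among the measured compounds shown here, no pair of measured compounds differs in one place, so no measured step exists yet.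

Compound 3 `CC(Sc1nc2c(cnn2C)c(=O)n1-c1ccccc1)c1cccc(O)c1` has not been measured. Against compound 1 the change is hydrogen in place of methyl on an oxygen on an aromatic ring. For the measured compounds named here, no measured pair carries this change, so nothing in the numbers speaks to its size or direction. The expectation therefore rests on compound 1 alone at 451 nM. The step of a 1.1-fold higher number from compound 1 to compound 3 (0.04 log units; within the scatter) is expected to fall within the scatter, with no clear direction. Compound 3 is estimated in this assay at 500 nM, with a range from 200 nM to 1300 nM.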

Compound 3, half-maximal inhibitory concentration in the aldehyde dehydrogenase 1A1 assay: 130 nM
Compound 3: the middle estimate sits 3.8-fold (0.59 log units) above what was measured; measured number outside the range, below it.
By their numbers in the aldehyde dehydrogenase 1A1 assay, from the lowest: compound 3; then compound 1; then compound 2.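

Among the compounds shown here, on an oxygen on an aromatic ring, hydrogen in place of methyl is the first single change measured, and in the aldehyde dehydrogenase 1A1 assay the step is a 3.5-fold lower number from compound 1 to compound 3 (0.54 log units; beyond the scatter). In a physicochemical assay for solubility, using the shake flask method, in phosphate buffer, with a stated time of 24 h, at pH 7.4 (a higher number here means a more soluble compound, a lower number a less soluble compound), compound 1 gives < 2000 nM, which is a limit of the assay and not a number. In the physicochemical assay compound 3 gives 21000 nM, so compound 3 holds both the lower inhibition number and the higher solubility number of this pair.

One replacement on this oxygen cannot separate the effect of the free hydroxy from that of losing the methyl, and an amine or a carboxylic acid in place of the hydroxy would test this. Going by these compounds, whether the change carries over to the core of compound 2 also stays open.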